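The source may hold more compounds than are shown below. What is called first, only, known or untested is meant among the compounds shown, and "the series" means these compounds.

Measured in a functional assay for inhibition, with Rattus norvegicus as the target, at pH 7.35; a lower number here means a stronger inhibitor, a higher number a weaker inhibitor:
- compound 1 `CCOC(=O)C(=O)C(CC)NC(=O)C(CC(C)C)NC(=O)OCc1ccccc1` gives 300000 nM
- compound 2 `CCCCCCCCNC(=O)C(=O)C(CC)NC(=O)C(CC(C)C)NC(=O)OCc1ccccc1` gives 200000 nM
- compound 3 `CCC(NC(=O)C(CC(C)C)NC(=O)OCc1ccccc1)C(=O)C(=O)NCCCc1ccccc1` gives 100000 nM

The three numbers span a narrow range. The only gap beyond the scatter is a 3.0-fold lower number from compound 1 to compound 3 (0.48 log units; beyond the scatter), a modest one, while a 2.0-fold lower number from compound 2 to compound 3 (0.30 log units; within the scatter) stays within it. Compound 3 therefore stands apart from compound 1 only, and not from compound 2.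

Compound 4 `CCC(NC(=O)C(CC(C)C)NC(=O)OCc1ccccc1)C(=O)C(=O)O` has hydroxy in place of (3-phenylpropyl)amino on a carbonyl carbon. Among the measured compounds shown here, no measured compound carries hydroxy at this carbonyl carbon, so there is no direct precedent. The nearest evidence is the change at the same place, where a 1.5-fold lower number from compound 1 to compound 2 (0.18 log units; within the scatter) lies within the scatter and a 3.0-fold lower number from compound 1 to compound 3 (0.48 log units; beyond the scatter) is modest. The reverse of that second step is the best available guide, since the small ethoxy group in compound 1 gives 300000 nM. A modest move to a higher number in this assay, meaning a weaker inhibitor, is expected, with the estimated step being a 3.0-fold higher number from compound 3 to compound 4 (0.48 log units; beyond the scatter). The estimate for compound 4 is 300000 nM, with an expected range of 100000 nM to 1000000 nM.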

Compound 4, half-maximal inhibitory concentration: 100000 nM
Compound 4: middle estimate off by 3.0-fold (0.48 log units), on the high side, and the stated range covers the measured number.
By their numbers in this assay, from the lowest: compounds 3, 4, 2 and 1 (each within the scatter of the next, the first and the last beyond it).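

On this carbonyl carbon in this assay, hydroxy replaces (3-phenylpropyl)amino with no change at the digits printed from compound 3 to compound 4 (within the scatter) and also replaces octylamino with a 2.0-fold lower number from compound 2 to compound 4 (0.30 log units; within the scatter), so neither amide side chain can be told apart from the free carboxy compound. Only the ethyl ester stands apart, with a 3.0-fold lower number from compound 1 to compound 4 (0.48 log units; beyond the scatter) on loss of its ethyl, so a small group at this carbon does not by itself go with a higher number, compound 1 fitting that link and compound 4 going against it. No data are available that explain these results.

As far as these compounds go, whether a primary amide, a morpholine amide or a benzylamino group here would separate from compound 3 stays open. Also open, from the compounds shown here alone, is whether a longer chain in place of the ethyl group on the shared core would move the number further than any change at this carbonyl carbon.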